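This account rests on a few compounds, and the source may have more. Where it says the series, first, only, none or still open, it means among the compounds named here.

Among the three compounds measured in a functional assay on HEK293 cells for positive allosteric modulation of metabotropic glutamate receptor 5 (Homo sapiens), read by calcium flux (a lower number here means a smaller maximal response, a higher number a larger maximal response), compound 3 `O=C(C1CC1)N1CCCn2nc(COc3ccccc3)cc21` gives 61%, the highest of the three numbers. Compound 2 `CC(C)C(=O)N1CCCn2nc(COc3ccccc3)cc21` gives 59%, and compound 1 `CCC(=O)N1CCCn2nc(COc3ccccc3)cc21` gives 48%. The step of a number 13 percentage points higher from compound 1 to compound 3 (beyond the scatter) was modest, while the step of a number 2 percentage points higher from compound 2 to compound 3 (within the scatter) stayed within the scatter. Compound 4 `O=C(C1CCC1)N1CCCn2nc(COc3ccccc3)cc21` differs from compound 3 by a single change: cyclobutyl in place of cyclopropyl on a carbonyl carbon. For the measured compounds named here, the steps that bear on it are the two earlier swaps of the group on the carbonyl carbon: ethyl to cyclopropyl brought the modest gain just noted, and isopropyl to cyclopropyl brought nothing beyond the scatter. A similarly small or absent shift in this assay is therefore expected, with a number 1 percentage points higher from compound 3 to compound 4 (within the scatter). Compound 4 is estimated at 62%, most likely between 50% and 74%.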

Compound 4, largest response reached (reported as percent of maximum), in percent of the reference or control that the assay uses: 41%
Estimate against measurement, compound 4: 21 percentage points above; the whole stated range lies above it.
By their numbers in this assay, from the lowest: compounds 4 and 1 (each within the scatter of the next); then compounds 2 and 3 (each within the scatter of the next).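

Cyclopropyl and isopropyl on this carbonyl carbon gave responses within the scatter of each other, but one more ring carbon is not tolerated as readily: cyclobutyl gives (a number 20 percentage points lower from compound 3 to compound 4 (beyond the scatter)) and (a number 18 percentage points lower from compound 2 to compound 4 (beyond the scatter)) in this assay for this series. Against ethyl, cyclobutyl gives (a number 7 percentage points lower from compound 1 to compound 4 (within the scatter)), so the gain seen with cyclopropyl and isopropyl is lost. No available evidence explains this drop.

On these data alone, whether cyclopentyl would lower the response further on this carbonyl carbon remains open. So does whether a tert-butyl or phenyl group would restore it.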